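The source may report more compounds than this note shows. Statements on the series, on what has been measured and on what is new or still open speak of the compounds shown alone.

Compound 1 `O=C(/C=C\Nc1ccc(F)cc1)c1cn(-c2ccccc2)nc1-c1ccc(F)cc1` is the reference point of this pair: in a functional assay on A549 cells (Homo sapiens) for antiproliferative activity, read by MTT assay, with a stated time of 48 h (on this read-out lower numbers stand for stronger inhibition and higher numbers for weaker inhibition), compound 1 gives 5780 nM. Compound 2 `O=C(/C=C\Nc1ccc(C(F)(F)F)cc1)c1cn(-c2ccccc2)nc1-c1ccc(F)cc1` carries trifluoromethyl where compound 1 carries fluoro. In this assay compound 2 gives > 50000 nM, which is a limit of the assay and not a number. Among the measured compounds shown here, the only measured step is therefore an at least 8.6-fold higher number from compound 1 to compound 2 (0.93 log units; beyond the scatter), and its size is bounded only from one side because of the limit of > 50000 nM in this assay, at which 1 of the 2 values shown sits.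

Compound 3 `O=C(/C=C\Nc1ccc(O)cc1)c1cn(-c2ccccc2)nc1-c1ccc(F)cc1` is the next compound to be measured. Its change from compound 2 is hydroxy in place of trifluoromethyl on an aromatic carbon. For the measured compounds named here, the trifluoromethyl that entered between compound 1 and compound 2 leaves again here, so the one measured step bears on this change in reverse, with hydroxy rather than fluoro as the end point. The expectation is that compound 3 moves back toward the value of compound 1, that is a drop in number in this assay of the order of an at least 6.2-fold lower number from compound 2 to compound 3 (0.79 log units; beyond the scatter), though only a lower bound of the forward step is known. The estimate for compound 3 in this assay is 8000 nM, with a range of 2500 nM to 30000 nM.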

Compound 3, half-maximal inhibitory concentration: 1500 nM
Beside the measured number, compound 3's estimate is 5.3-fold (0.73 log units) above it; the whole stated range lies above it.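

Hydroxy on this aromatic carbon, para to a large group, gives the first step in this assay toward a lower number, a 3.9-fold lower number from compound 1 to compound 3 (0.59 log units; beyond the scatter), so the earlier finding of a loss with trifluoromethyl is now joined by a gain at the same place. Against trifluoromethyl the same group gives an at least 33-fold lower number from compound 2 to compound 3 (1.52 log units; beyond the scatter), and compound 3 carries the lowest number of the three, which shows that this position responds in both directions and that the group held there has a large effect on the read-out. Compound 2 stands at a limit of the assay and not at a number, so the true size of that step stays bounded from one side only: the limit of > 50000 nM in this assay, at which 1 of the 3 values shown sits.

Hydroxy differs from fluoro and from trifluoromethyl in its hydrogen-bond donor and acceptor counts, and three compounds cannot show whether those counts or some other difference sets the order; a methoxy group or an amine at the same place would bear directly on that. On these data alone, whether the same order holds with the other parts of the shared core changed also remains open.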